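The source may report more compounds than this note shows. Statements on the series, on what has been measured and on what is new or still open speak of the compounds shown alone.

Compound 1, `FC(F)(F)c1cccc(N2CCC(NC(=S)Nc3cccnc3)CC2)n1`, gives 630 nM in an assay on membranes from brain for binding affinity to Lysophosphatidylserine lipase ABHD12 (Mus musculus), read by fluorescence, with a stated time of 20 min; on this read-out higher numbers stand for weaker inhibition and lower numbers for stronger inhibition.
Compound 2, `FC(F)(F)c1ccnc(N2CCC(NC(=S)Nc3cccnc3)CC2)c1`, gives 640 nM in this assay.
Compound 3, `FC(F)(F)c1ccnc(N2CCC(NC(=S)Nc3cccnc3)CC2)c1Cl`, gives 300 nM in this assay.

Compound 2 stands at the highest of the three numbers, though its value and that of compound 1 sit within the scatter of each other, so no order between those two can be read. Only compound 3 is set apart, by a 2.1-fold lower number from compound 2 to compound 3 (0.33 log units; beyond the scatter).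

Compound 4, `COc1ccc(Oc2ccnc(N3CCC(NC(=S)Nc4cccnc4)CC3)c2)cc1`, differs from compound 2 in one place: 4-methoxyphenoxy in place of trifluoromethyl on an aromatic carbon. Among the compounds with values here, no measured step of this kind exists among the three compounds. Within the data shown here, the one measured step, a 2.1-fold lower number from compound 2 to compound 3 (0.33 log units; beyond the scatter), concerns a different replacement at a different carbon and gives no direct guide to an exchange of this size. The expectation is therefore anchored on compound 2 itself, with wide bounds in both directions. Compound 4 is estimated at 450 nM, within 100 nM to 2000 nM, which means an expected step of a 1.4-fold lower number from compound 2 to compound 4 (0.15 log units; within the scatter).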

Compound 4, half-maximal inhibitory concentration: 2900 nM
The estimate for compound 4 lay 6.4-fold (0.81 log units) below the measured number; the measured number lies above the stated range.
By their numbers in this assay, from the lowest: compound 3; then compounds 1 and 2 (each within the scatter of the next); then compound 4.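

In this assay, the aromatic carbon opposite the ring nitrogen proves sensitive to the group it carries: 4-methoxyphenoxy in place of trifluoromethyl weakens inhibition (a 4.5-fold higher number from compound 2 to compound 4 (0.66 log units; beyond the scatter)). This is the first change at this carbon among the compounds shown, and it runs in the opposite direction to the chloro replacement at another carbon (a 2.1-fold lower number from compound 2 to compound 3 (0.33 log units; beyond the scatter)), while compound 4 still gives a measurable 2900 nM with the added aromatic ring in place. Nothing in the available evidence accounts for this loss.

The compounds leave open whether the loss follows from the ring, the ether oxygen or the terminal methoxy, since none carries a plain methoxy, a phenoxy without the methoxy, or a phenyl at this carbon. They also leave open how an amine or a carboxylic acid would fare there.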